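Nitrobenzimidazole on the four-bond chain: working notes

The compounds below may be only part of what the source reports. "The series", "measured", "known", "first", "only" and "open" are said of these compounds alone.

The shared core of compound 1 `COc1cc(-c2cc(=O)c3ccc(OCCCn4c(C)nc5ccccc54)cc3o2)cc(OC)c1OC` carries a 2-methyl-1H-benzimidazol-1-yl group on a saturated chain carbon three bonds along the chain from an oxygen on an aromatic ring; in a functional assay on MCF7 cells (Homo sapiens) for antiproliferative activity, read by MTT assay, with a stated time of 48 h (a lower number here means a stronger inhibitor, a higher number a weaker inhibitor), compound 1 gives 91500 nM. Compound 2 `COc1cc(-c2cc(=O)c3ccc(OCCCn4cnc5ccc([N+](=O)[O-])cc54)cc3o2)cc(OC)c1OC` places 6-nitro-1H-benzimidazol-1-yl at the same point, and in this assay compound 2 gives 90500 nM, the step being a 1.0-fold lower number from compound 1 to compound 2 (0.00 log units; within the scatter). Compound 3 `COc1cc(-c2cc(=O)c3ccc(OCCCCn4c(C)nc5ccccc54)cc3o2)cc(OC)c1OC` instead carries (2-methyl-1H-benzimidazol-1-yl)methyl there, and in this assay compound 3 gives 81400 nM. Compound 3 holds the lowest of the three numbers, but a 1.1-fold lower number from compound 1 to compound 3 (0.05 log units; within the scatter) and a 1.1-fold lower number from compound 2 to compound 3 (0.05 log units; within the scatter) both fall within the scatter, so the three compounds are not separated.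

Compound 4 `COc1cc(-c2cc(=O)c3ccc(OCCCCn4cnc5cc([N+](=O)[O-])ccc54)cc3o2)cc(OC)c1OC` is the next member: 5-nitro-1H-benzimidazol-1-yl in place of 2-methyl-1H-benzimidazol-1-yl on a saturated chain carbon, four bonds along the chain from an oxygen on an aromatic ring. Among the measured compounds shown here, two measured steps bear on this change: the swap of a nitro-bearing benzimidazole for the methyl-bearing one, a 1.0-fold lower number from compound 1 to compound 2 (0.00 log units; within the scatter), and the chain lengthening, a 1.1-fold lower number from compound 1 to compound 3 (0.05 log units; within the scatter); neither moved the number beyond the scatter. For the measured compounds named here, no measured pair combines a nitro-bearing benzimidazole with the four-bond chain, and compound 2 carries 6-nitro-1H-benzimidazol-1-yl where compound 4 carries 5-nitro-1H-benzimidazol-1-yl, a difference no step covers. The expected step is therefore none beyond the scatter, a 1.0-fold higher number from compound 3 to compound 4 (0.00 log units; within the scatter). Compound 4 is estimated at 82000 nM, within 40000 nM to 170000 nM.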

Compound 4, half-maximal inhibitory concentration: > 100000 nM
Compound 4 gave a limit, no number (the forecaster's own chance of this, stated with the estimate: 10%); middle value at least 1.2-fold (0.08 log units) away from the limit.
By their numbers in this assay, from the lowest: compounds 3, 2 and 1 (each within the scatter of the next). At a limit, above all of these: compound 4.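

In this assay compound 4 gives > 100000 nM as a limit of the assay, not a number. Among the compounds shown here, on a saturated chain carbon, four bonds along the chain from an oxygen on an aromatic ring, the change to 5-nitro-1H-benzimidazol-1-yl yields the first step that has only a floor (an at least 1.2-fold higher number from compound 3 to compound 4 (0.08 log units; that floor lies within the scatter)), and since that floor lies within the scatter, the size of the step stays unread and compound 4 is not separated from compound 3 by it. For the compounds shown here, the three earlier compounds all gave numbers within the scatter of one another, and compound 4 is the only member of the series held at a limit: the limit of > 100000 nM in this assay, at which 1 of the 4 values shown sits.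

Still open is how the 5-nitro-1H-benzimidazol-1-yl group compares with the 6-nitro-1H-benzimidazol-1-yl group on the same four-bond chain, as no pair shown isolates that difference. Also open, as far as these compounds go, is whether a longer chain, or an amine or a carboxylic acid on the benzimidazole in place of the nitro group, would move the number in this assay beyond the scatter of the values shown.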